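Quinazoline series: benzyl to carbamoyl on the piperidine carbon

The compounds below may be only part of what the source reports. "The series", "measured", "known", "first", "only" and "open" are said of these compounds alone.

Measured compounds and values in an in vitro functional assay on B300-19 cells for antagonist activity at C-C chemokine receptor type 4 (Homo sapiens), read by GTPgammaS binding, tested at 1 uM; a higher number here means more inhibition at the concentration tested (going by the name of the read-out), a lower number less inhibition:
compound 1 `COc1ccc2c(NC3CCCCCC3)nc(N3CCC(N4CCCC4)CC3)nc2c1`, compound 1 gives 10%
compound 2 `c1ccc2c(NC3CCCCCC3)nc(N3CCC(N4CCCC4)CC3)nc2c1`, compound 2 gives 10%
compound 3 `COc1cc2nc(N3CCC(Cc4ccccc4)CC3)nc(NC3CCCCCC3)c2cc1OC`, compound 3 gives 1%

All three measured compounds show little inhibition at the concentration tested. Compound 3 has the lowest number of the three, but its gap to compound 1 and to compound 2 lies within the scatter, so no order among them can be drawn. For the measured compounds named here, the only step measured between two compounds that differ in one place, no change at the digits printed from compound 1 to compound 2 (within the scatter), concerns an aromatic carbon and does not touch the place changed here.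

Compound 4 `COc1cc2nc(N3CCC(C(N)=O)CC3)nc(NC3CCCCCC3)c2cc1OC` is the next compound to be measured. Its change from compound 3 is carbamoyl in place of benzyl on a saturated ring carbon. Going by the values given here, no measured step covers a change at this saturated ring carbon, so the expectation rests only on the level of compound 3. Compound 4 is expected to stay in the same low range, with an estimated step of a number 4 percentage points higher from compound 3 to compound 4 (within the scatter), nothing beyond the scatter. For compound 4 the estimate in this assay is 5%, with a range from -10% to 20%.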

Compound 4, a percentage reported as inhibition, at one concentration (the size of the read-out at that concentration, not a potency): 17%
Compound 4: the middle estimate sits 12 percentage points below what was measured, within the range that was stated.
By their numbers in this assay, from the lowest: compounds 3, 1, 2 and 4 (each within the scatter of the next, the first and the last beyond it).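

In this assay the saturated ring carbon responds to the exchange of benzyl for carbamoyl, with a number 16 percentage points higher from compound 3 to compound 4 (beyond the scatter) as a modest step. For the compounds shown here, the only earlier step was no change at the digits printed from compound 1 to compound 2 (within the scatter) at an aromatic carbon, so this is the first single change that lies beyond the scatter. No measurement at hand bears on why the number moves at this carbon.

On these data alone, with compound 4 at 17% inhibition remains modest, and it stays open whether the step belongs to the arrival of carbamoyl or to the departure of benzyl. A primary amine, a carboxylic acid or a longer chain ending in carbamoyl on the same carbon would help to separate these two readings.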